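Swapping the Acyl Group on a Ring Nitrogen

The compounds below may be only part of what the source reports. "The series", "measured", "known", "first", "only" and "open" are said of these compounds alone.

Compound 1, `CC1=C(C(=O)OC(C)C)C(c2cccc([N+](=O)[O-])c2)NC(=O)N1`: 58100 nM
Compound 2, `COC(=O)N1C(=O)NC(C)=C(C(=O)OC(C)C)C1c1cccc([N+](=O)[O-])c1`: 2480 nM

Both compounds were tested in an assay on HEK293 cells for antagonist activity at Voltage-dependent L-type calcium channel subunit alpha-1C (Oryctolagus cuniculus), read by FLIPR; a higher number here means a weaker inhibitor, a lower number a stronger inhibitor. For the measured compounds named here, compound 2 stands at the lower of the two numbers measured so far, with compound 1 as its only neighbour at a clearly higher number. Going by the values given here, the one known step, a 23-fold lower number from compound 1 to compound 2 (1.37 log units; beyond the scatter), came from adding a methoxycarbonyl group to the amide-type nitrogen in the ring, and it was large. Compound 3, `CC1=C(C(=O)OC(C)C)C(c2cccc([N+](=O)[O-])c2)N(C(=O)C(C)C)C(=O)N1`, keeps that nitrogen acylated and changes only the far end of the group: isopropyl in place of methoxy on a carbonyl carbon. Among the compounds with values here, no measured pair shows what this particular exchange does. Within the data shown here, the only step that bears on it is a 23-fold lower number from compound 1 to compound 2 (1.37 log units; beyond the scatter), which shows that placing a carbonyl-bearing group on this nitrogen goes with a much lower number. Because compound 2 already carries such a group and gives 2480 nM, the change to compound 3 is expected to stay within the scatter. Compound 3 is therefore estimated to give 2500 nM (800 nM to 8000 nM), an expected step of a 1.0-fold higher number from compound 2 to compound 3 (0.00 log units; within the scatter).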

Compound 3, half-maximal inhibitory concentration: 500 nM
Compound 3: the middle estimate sits 5.0-fold (0.70 log units) above what was measured, outside the stated range (below it).
By their numbers in this assay, from the lowest: compound 3; then compound 2; then compound 1.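

The result shows that in this assay it is not enough for this nitrogen simply to carry a carbonyl-bearing group, since the far end of that group also counts: isopropyl in place of methoxy on a carbonyl carbon whose other neighbour is the amide-type nitrogen in a ring gives a 5.0-fold lower number from compound 2 to compound 3 (0.70 log units; beyond the scatter). Set against hydrogen on the same nitrogen, the isopropylcarbonyl group gives a 120-fold lower number from compound 1 to compound 3 (2.07 log units; beyond the scatter), so the size of the drop depends on which group is attached, and it goes further here than with methoxycarbonyl. Nothing available explains the difference between the isopropyl and methoxy ends, and this single exchange gives no reason for it.

Still open, as far as these compounds go, is how the number responds to other groups on this carbonyl carbon, such as a longer chain like n-butyl, a cyclopropyl ring, a phenyl ring or a dimethylamino group, and whether the trend from methoxy to isopropyl would continue with any of them. From the compounds shown here alone, it is also open whether the same exchange would have a similar effect if the isopropyl ester elsewhere on the core were replaced by a methyl ester.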